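Swapping chloro for methyl on compound 3's pyridinyl group

A few compounds are considered here, and "the series" means these few. Any claim that something is new, unique, unknown or untested is made for them only; others in the source may bear on it.

Compound 1 `COc1cccc(Cn2cnc3sc(-c4ccc5[nH]ncc5c4)cc3c2=O)c1` gives 2 nM in an assay on isolated protein for inhibition of Rho-associated protein kinase 2 (Homo sapiens), read by radiometric assay and 33P incorporation, with a stated time of 40 min, in the presence of a further agent that is not named here; on this read-out higher numbers stand for weaker inhibition and lower numbers for stronger inhibition.
Compound 2 `COc1cccc(Cn2cnc3sc(-c4cccnc4)cc3c2=O)c1` gives 3480 nM in this assay.
Compound 3 `COc1cccc(Cn2cnc3sc(-c4ccnc(Cl)c4)cc3c2=O)c1` gives 501 nM in this assay.

Compound 3 stands second highest of the three numbers. Its nearest neighbour is compound 2, with a 6.9-fold lower number from compound 2 to compound 3 (0.84 log units; beyond the scatter) separating them, while compound 1 lies far off, with a 250-fold higher number from compound 1 to compound 3 (2.40 log units; beyond the scatter) between them. Both of these steps exchange one whole aromatic group for another, so they speak to how much the group attached to the shared core matters, but neither of them changes a single small substituent.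

Compound 4 `COc1cccc(Cn2cnc3sc(-c4ccnc(C)c4)cc3c2=O)c1` differs from compound 3 by methyl in place of chloro on an aromatic carbon. The chloro that leaves and the methyl that enter each count one heavy atom, and neither adds or removes a hydrogen-bond donor or acceptor. For the measured compounds named here, no measured step swaps one such small group for another on the same aromatic carbon, so the measured steps give only a loose guide. In this assay the change is therefore expected to produce a step no larger than the usual scatter, with direction uncertain, so that the expected step is a 1.0-fold lower number from compound 3 to compound 4 (0.00 log units; within the scatter). The estimated value for compound 4 is 500 nM, with an expected range from 150 nM to 1600 nM.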

Compound 4, half-maximal inhibitory concentration: 42 nM
For compound 4 the middle estimate is 12-fold (1.08 log units) above the measured one, and the stated range ends above it.
By their numbers in this assay, from the lowest: compound 1; then compound 4; then compound 3; then compound 2.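

On the 2-chloropyridin-4-yl group, exchanging one small substituent for another with the same heavy-atom count has a large effect in this assay and gives a 12-fold lower number from compound 3 to compound 4 (1.08 log units; beyond the scatter) on an aromatic carbon next to the ring nitrogen. For the compounds shown here, earlier steps exchanged whole aromatic groups, so this is the first sign that a single small substituent at this place can matter as well. The 2-methylpyridin-4-yl group also stands well clear of the pyridin-3-yl group, with an 83-fold lower number from compound 2 to compound 4 (1.92 log units; beyond the scatter) in the same assay, and it closes much of the distance to the 1H-indazol-5-yl group, although a 21-fold higher number from compound 1 to compound 4 (1.32 log units; beyond the scatter) still remains.

No measurement shown here explains why methyl and chloro differ so strongly at this place. Going by these compounds, it also remains open whether methyl strengthens inhibition or chloro weakens it, which would take a comparison with plain hydrogen at this place, and whether an amine, a methoxy group or a longer chain such as ethyl would lower the number further.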